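The source may report more compounds than this note shows. Statements on the series, on what has been measured and on what is new or still open speak of the compounds shown alone.

Compound 2 `O=C(C1CCC(F)(F)CC1)N1CCc2nc(C#Cc3ccccc3)sc2C1` carries a 4,4-difluorocyclohexyl on the carbonyl carbon of the shared core. In an assay on HEK293 cells for positive allosteric modulation of metabotropic glutamate receptor 5 (Homo sapiens), read by FLIPR, with a stated time of 1 h (a lower number here means that less compound is needed, a higher number that more compound is needed for the effect), compound 2 gives 70 nM, the lowest of the two numbers obtained so far. Among the compounds with values here, the only other measured compound, compound 1 `COC1CC(C(=O)N2CCc3nc(C#Cc4ccccc4)sc3C2)C1`, gives 640 nM in this assay, and the single step on record, a 9.1-fold lower number from compound 1 to compound 2 (0.96 log units; beyond the scatter), separates them. Compound 3 `O=C(N1CCCCC1)N1CCc2nc(C#Cc3ccccc3)sc2C1` differs from compound 2 in one place: piperidin-1-yl in place of 4,4-difluorocyclohexyl on a carbonyl carbon. Within the data shown here, no measured step bears directly on this change, since the one known step trades two rings of carbon only against each other on the same carbonyl carbon; it shows merely that the group at that position can shift the number well beyond the scatter. Compound 3 is therefore expected to land near 200 nM, within 40 nM to 1000 nM. The step this estimate implies, a 2.9-fold higher number from compound 2 to compound 3 (0.46 log units; beyond the scatter), is expected to be a modest move toward a higher number.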

Compound 3, half-maximal effective concentration: 75 nM
Estimate against measurement, compound 3: 2.7-fold (0.43 log units) above; low and high end bracket the measured number.
By their numbers in this assay, from the lowest: compounds 2 and 3 (each within the scatter of the next); then compound 1.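

Exchanging 4,4-difluorocyclohexyl for piperidin-1-yl on the carbonyl carbon gives a 1.1-fold higher number from compound 2 to compound 3 (0.03 log units; within the scatter) in this assay, so at this position a six-membered ring attached through its nitrogen and carrying no fluorine matches the six-membered ring of carbon only. The change from 3-methoxycyclobutyl to piperidin-1-yl gives an 8.5-fold lower number from compound 1 to compound 3 (0.93 log units; beyond the scatter), which sets compound 3 with compound 2, both apart from compound 1. Nothing at hand explains why these two different rings give matching numbers.

The compounds shown leave open whether the unfluorinated cyclohexyl, with carbon in place of the piperidine nitrogen, would keep the number. They also leave open how morpholin-4-yl, pyrrolidin-1-yl or an open-chain diethylamino group would behave on the same carbonyl carbon.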